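Series notes: removing the aryl ether substituent

A few compounds are considered here, and "the series" means these few. Any claim that something is new, unique, unknown or untested is made for them only; others in the source may bear on it.

Compound 1 `O=c1c(Cc2coc3cccc(OCC4CCCCC4)c3c2=O)coc2ccccc12` carries a cyclohexylmethoxy group; in a functional assay on NCI-H23 cells (Homo sapiens) for antiproliferative activity, read by XTT assay (on this read-out lower numbers stand for stronger inhibition and higher numbers for weaker inhibition), compound 1 gives 4130 nM. Compound 2 `CC(C)CCOc1cccc2occ(Cc3coc4ccccc4c3=O)c(=O)c12` is the isopentyloxy analogue. In this assay compound 2 reaches only the limit of the assay, > 10000 nM, so compound 2 stands at the weak end of the numbers shown. Within the data shown here, the one measured step, an at least 2.4-fold higher number from compound 1 to compound 2 (0.38 log units; beyond the scatter), went toward weaker inhibition, in line with the limit of > 10000 nM in this assay, at which 1 of the 2 values shown sits. Compound 3 `O=c1c(Cc2coc3ccccc3c2=O)coc2ccccc12` differs from compound 2 by hydrogen in place of isopentyloxy on an aromatic carbon. Among the measured compounds shown here, no measured step removes the ether group altogether, so neither direction nor size can be read from the series; both measured compounds are weak. Compound 3 is therefore expected to remain weak, with a number no higher from compound 2 to compound 3 (the limit leaves the size open) as the estimated step. The estimate for compound 3 in this assay is 10000 nM, from 3000 nM to 30000 nM.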

Compound 3, half-maximal inhibitory concentration: 1400 nM
The estimate for compound 3 lay 7.1-fold (0.85 log units) above the measured number, and the stated range ends above it.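

In this assay, hydrogen in place of isopentyloxy gives an at least 7.1-fold lower number from compound 2 to compound 3 (0.85 log units; beyond the scatter), and hydrogen in place of cyclohexylmethoxy gives a 3.0-fold lower number from compound 1 to compound 3 (0.47 log units; beyond the scatter). Both ethers therefore go the same way, with compound 3 the stronger of each pair, so neither ether group is required on this aromatic carbon for the activity seen, and neither adds to it. The value of compound 2 is a limit and not a number, so the first of these steps gives only a bound on the size of the change: the limit of > 10000 nM in this assay, at which 1 of the 3 values shown sits.

The compounds shown leave open whether any group on this carbon can improve on hydrogen, since only the two larger ethers stand against it. A methoxy, a hydroxyl or an amine here would show whether the loss holds for small groups as well.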